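The compounds below may be only part of what the source reports. "The series", "measured", "known", "first", "only" and "open" are said of these compounds alone.

Of the compounds shown here, three sharing one core have been measured in a functional assay (QGY7701 cells, Homo sapiens) for inhibition, read by MTT assay, with a stated time of 48 h; a lower number here means a stronger inhibitor, a higher number a weaker inhibitor. Compound 1 `COc1ccc2c(=O)c(/C=C/C(=O)Nc3ccccc3)coc2c1` gives 14000 nM, the lowest of the three numbers shown, though only its gap to compound 2 lies beyond the scatter. Compound 3 `O=C(/C=C/c1coc2cc(O)ccc2c1=O)Nc1ccccc1`, which carries hydrogen in place of methyl on an oxygen on an aromatic ring, gives 17900 nM; that change appears as a 1.3-fold higher number from compound 1 to compound 3 (0.11 log units; within the scatter). Compound 2 `O=C(/C=C/c1coc2cc(O)ccc2c1=O)NCc1ccccc1`, with benzyl in place of phenyl on the amide-type nitrogen, gives 63000 nM, and the step of a 3.5-fold lower number from compound 2 to compound 3 (0.55 log units; beyond the scatter) shows that the group on that nitrogen can move the number.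

Compound 4 `COc1ccc2c(=O)c(/C=C/C(=O)Nc3ccccc3OC)coc2c1` differs from compound 1 by methoxy in place of hydrogen on an aromatic carbon. Neither measured step adds a group to that ring, so nothing measured bears directly on this change; the nearest analogy, on the amide side, moved the number only modestly. In this assay the expected step is therefore a 1.2-fold lower number from compound 1 to compound 4 (0.07 log units; within the scatter), not beyond the scatter. Compound 4 is expected to give 12000 nM, estimated between 4000 nM and 40000 nM.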

Compound 4, half-maximal inhibitory concentration: 17600 nM
Beside the measured number, compound 4's estimate is 1.5-fold (0.17 log units) below it, within the range that was stated.
By their numbers in this assay, from the lowest: compounds 1, 4 and 3 (each within the scatter of the next); then compound 2.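

In this assay, going from phenyl to 2-methoxyphenyl on the amide-type nitrogen gives a 1.3-fold higher number from compound 1 to compound 4 (0.10 log units; within the scatter), so this change cannot be told apart from repeat-measurement scatter. Within the data shown here, the earlier steps altered the oxygen substituent on the core and swapped phenyl for benzyl, whereas this is the first measured change on the aromatic ring of the amide side. It shows that a methoxy group can stand ortho to a large group there with no step beyond the scatter, and no measurement shown explains this result.

From the compounds shown here alone, whether a different group in this place, such as an amine, a carboxylic acid or a chlorine atom, would move the number stays open. So does whether the same methoxy group would give a similar step on compound 3 or on the benzyl group of compound 2.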